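Acetyl to dimethylamino on the aryl of compound 1

The source may hold more compounds than are shown below. What is called first, only, known or untested is meant among the compounds shown, and "the series" means these compounds.

Measured in a functional assay on OVCAR-3 cells (Homo sapiens) for cytotoxicity, read by sulforhodamine B assay, with a stated time of 48 h, tested at 0.01 uM; a lower number here means a stronger effect, a higher number a weaker effect of the compound at the concentration tested:
- compound 1 `COc1cc(C)cc(-c2c(-c3ccnc(-c4ccc(C(C)=O)cc4)c3)cnn2CC#N)c1`: 106%
- compound 2 `COc1cc(C)cc(-c2nn(CC#N)cc2-c2ccc(-c3cccc(C(C)=O)c3)nc2)c1`: 104%
- compound 3 `COc1cc(C)cc(-c2nn(CC#N)cc2-c2ccnc(-c3ccc(N(C)C)cc3)c2)c1`: 95%

Compound 1 holds the highest of the three numbers in this assay. Its nearest neighbour is compound 2, whose number is lower by an amount within the usual scatter, so the two are not ordered. Compound 3, which also carries a dimethylamino group but on a differently arranged core, sits furthest from compound 1, with a gap beyond the scatter. All three numbers stand close to full cell growth, so none of the compounds shows more than a marginal effect at the concentration tested.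

Compound 4 `COc1cc(C)cc(-c2c(-c3ccnc(-c4ccc(N(C)C)cc4)c3)cnn2CC#N)c1` is the next member, not yet measured. It differs from compound 1 in one place: dimethylamino in place of acetyl on an aromatic carbon The new group sits para to a large group, in the same position the acetyl group occupied.

Going by the values given here, no step between measured compounds isolates this exchange. With compound 3 at 95% as the only other dimethylamino bearer, a small drift downward is expected, and the step of a number 7 percentage points lower from compound 1 to compound 4 (within the scatter) is estimated to stay within the scatter. Compound 4 is therefore expected to read about 99% in this assay, in a range from 87% to 110%.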

Compound 4, a percentage reported as activity, at one concentration (the size of the read-out at that concentration, not a potency): 63%
The estimate for compound 4 lay 36 percentage points above the measured number, outside the stated range (below it).
By their numbers in this assay, from the lowest: compound 4; then compounds 3, 2 and 1 (each within the scatter of the next, the first and the last beyond it).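

In this assay, going by these compounds alone, the exchange gives a number 43 percentage points lower from compound 1 to compound 4 (beyond the scatter), so the aromatic carbon para to a large group on the shared core responds to the group it carries, which no earlier pair could show. The heavy-atom, hydrogen-bond donor and hydrogen-bond acceptor counts stay the same across this change, so those counts do not separate 4-acetylphenyl from 4-(dimethylamino)phenyl. Nothing at hand gives a measured reason for the size of this step.

Open, as far as these compounds go, is whether the step belongs to dimethylamino alone or would also appear with another amine at this place, such as pyrrolidine or morpholine, or with a non-nitrogen group such as methoxy. Also open, from the compounds shown here alone, is how compound 4 behaves at other concentrations, as one concentration gives the size of an effect and not a potency.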